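The source may report more compounds than this note shows. Statements on the series, on what has been measured and on what is new or still open speak of the compounds shown alone.

Compound 1, `CS/C(=N\C(=O)c1csc([N+](=O)[O-])c1)NC(=O)c1csc([N+](=O)[O-])c1`, gives 41500 nM in a functional assay on PC-3 cells (Homo sapiens) for cytotoxicity, read by MTT assay, with a stated time of 72 h; on this read-out lower numbers stand for stronger inhibition of growth and higher numbers for weaker inhibition of growth. Compound 2, `CS/C(=N\C(=O)c1cc(-c2ccccc2)nc2ccccc12)NC(=O)c1cc(-c2ccccc2)nc2ccccc12`, gives 7480 nM. Compound 3, `O=C(/N=C(/NC(=O)c1csc([N+](=O)[O-])c1)[Se]Cc1ccccc1)c1csc([N+](=O)[O-])c1`, gives 35900 nM.

Compound 3 stands second highest of the three numbers; its value and that of compound 1 lie within the usual scatter of each other, while compound 2 shows a lower number, beyond the scatter. Compound 4, `C[Se]/C(=N\C(=O)c1csc([N+](=O)[O-])c1)NC(=O)c1csc([N+](=O)[O-])c1`, carries hydrogen in place of phenyl on a saturated chain carbon bound to a selenium atom. For the measured compounds named here, the only measured step that touches this part of the shared core is a 1.2-fold lower number from compound 1 to compound 3 (0.06 log units; within the scatter), in which a larger group in place of a smaller one on the same carbon changed the number little. The step to compound 4 is therefore expected to be small, a 1.1-fold higher number from compound 3 to compound 4 (0.02 log units; within the scatter), with no clear direction. For compound 4 the estimate is 38000 nM, expected to fall between 19000 nM and 76000 nM.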

Compound 4, concentration for 50% growth inhibition: 100 nM
Compound 4: middle estimate off by 380-fold (2.58 log units), on the high side, outside the stated range (below it).
By their numbers in this assay, from the lowest: compound 4; then compound 2; then compounds 3 and 1 (each within the scatter of the next).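

Changing benzyl to methyl on selenium gives a 360-fold lower number from compound 3 to compound 4 (2.56 log units; beyond the scatter), so the group at this position matters far more than the flat step a 1.2-fold lower number from compound 1 to compound 3 (0.06 log units; within the scatter) suggested. Selenium in place of sulfur, with the methyl kept, gives a 420-fold lower number from compound 1 to compound 4 (2.62 log units; beyond the scatter), so the two atoms are not interchangeable here when the group on them is small. The data offer no explanation for either jump. Still open, going by these compounds, is whether an ethyl group or a longer chain on selenium keeps this strong inhibition of growth. Also open, on these data alone, is whether methyl on selenium does the same on the core of compound 2.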